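A few compounds are considered here, and "the series" means these few. Any claim that something is new, unique, unknown or untested is made for them only; others in the source may bear on it.

Compound 1 `Sc1[nH]ccc2ncnc1-2` — 8 mg/kg
Compound 2 `CN(C)c1[nH]ccc2ncnc1-2` — 9 mg/kg

In a functional assay on the whole organism (Pleural cavity) with Rattus norvegicus as the target (a lower number here means that less compound is needed, a higher number that more compound is needed for the effect), compound 2 gives the highest of the two numbers, yet the step of a 1.1-fold higher number from compound 1 to compound 2 (0.05 log units; within the scatter) falls within the scatter, so the two compounds cannot be ranked. Compound 3 `Nc1[nH]ccc2ncnc1-2` differs from compound 2 by one change: amino in place of dimethylamino on an aromatic carbon. Among the compounds with values here, no measured step alters this group, and the one step measured, a 1.1-fold higher number from compound 1 to compound 2 (0.05 log units; within the scatter), was within the scatter, so no shift beyond the scatter is expected. Compound 3 is estimated at 9 mg/kg, in a range from 4 mg/kg to 20 mg/kg, which means an expected step of no change at the digits printed from compound 2 to compound 3 (within the scatter).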

Compound 3, dose for half-maximal effect: 8 mg/kg
Estimate against measurement, compound 3: 1.1-fold (0.05 log units) above; low and high end bracket the measured number.
By their numbers in this assay, from the lowest: compounds 1, 3 and 2 (each within the scatter of the next).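

At this aromatic carbon next to the ring nitrogen, amino in place of dimethylamino gives a 1.1-fold lower number from compound 2 to compound 3 (0.05 log units; within the scatter) in this assay, and amino in place of sulfanyl gives no change at the digits printed from compound 1 to compound 3 (within the scatter). Sulfanyl, dimethylamino and amino therefore cannot be ranked here, and the hydrogen-bond donor that amino carries and dimethylamino lacks comes with no shift beyond the scatter. No evidence is available that bears on this result. The compounds shown leave open whether a carboxylic acid or a phenyl ring at this carbon would move the number beyond the scatter.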